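The compounds below may be only part of what the source reports. "The series", "measured", "known", "first", "only" and "open" are said of these compounds alone.

In a functional assay on cells (Homo sapiens) for antiproliferative activity, read by WST assay, with a stated time of 3 days (a higher number here means a weaker inhibitor, a lower number a stronger inhibitor), compound 1 `[N-]=[N+]=Nc1cc(=O)[nH]c(=O)n1[C@@H]1O[C@H](CO)[C@@H](O)[C@H]1O` reads > 50000 nM, which is a limit and not a number. Among the measured compounds shown here, compound 2 `[N-]=[N+]=Nc1c(F)c(=O)[nH]c(=O)n1[C@@H]1O[C@H](CO)[C@@H](O)[C@H]1O` gives 600 nM, the only actual number so far. The step of an at least 83-fold lower number from compound 1 to compound 2 (1.92 log units; beyond the scatter) is large, but it concerns the fluoro group, which compound 3 `O=Cc1c(F)c(=O)[nH]c(=O)n1[C@@H]1O[C@H](CO)[C@@H](O)[C@H]1O` keeps. Compound 3 instead carries formyl in place of azido on an aromatic carbon, ortho to a fluoro group (formyl in place of azido on an aromatic carbon). For the measured compounds named here, no measured step covers this exchange, so the expectation is loose. With compound 2 at 600 nM, and an at least 83-fold lower number from compound 1 to compound 2 (1.92 log units; beyond the scatter) showing how far one small change can move this series, a sizeable loss in this assay is expected, as the estimated 10-fold higher number from compound 2 to compound 3 (1.00 log units; beyond the scatter). The estimate for compound 3 is 6000 nM, with an expected range of 800 nM to 50000 nM.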

Compound 3, half-maximal inhibitory concentration: 400 nM
Compound 3: middle estimate off by 15-fold (1.18 log units), on the high side, and the stated range ends above it.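

Azido is not required at this position: with the fluoro group kept, formyl in place of azido gives a 1.5-fold lower number from compound 2 to compound 3 (0.18 log units; within the scatter) in this assay, so compound 2 and compound 3 cannot be told apart. Activity at this level therefore holds across two different groups here, on the aromatic carbon ortho to the fluoro group. Compound 1, which has hydrogen in place of that fluoro group, is the one compound read only as a limit: the limit of > 50000 nM in this assay, at which 1 of the 3 values shown sits.

On these data alone, whether the fluoro group matters as much alongside formyl remains open. So does the response of this position to an amine, a carboxylic acid or a nitrile.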